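The source may report more compounds than this note shows. Statements on the series, on what has been measured and on what is new or still open speak of the compounds shown alone.

In a functional assay on RS4-11 cells (Homo sapiens) for inhibition, read by CCK-8 assay, with a stated time of 48 h, tested at 20 uM (a lower number here means less inhibition of growth, a higher number more inhibition of growth at the concentration tested), compound 1 (`COc1ccc(Cc2nnc(NC(=O)/C(C#N)=C/c3ccccc3OS(=O)(=O)c3ccccc3[N+](=O)[O-])s2)cc1`) gives 68% and compound 2 (`COc1ccc(S(=O)(=O)Oc2ccccc2/C=C(\C#N)C(=O)Nc2nnc(Cc3ccccc3)s2)cc1`) gives 78% within the scatter of each other. Compound 3 (`N#C/C(=C\c1ccccc1OS(=O)(=O)c1ccccc1[N+](=O)[O-])C(=O)Nc1nnc(Cc2ccccc2)s1`) carries 2-nitrophenyl in place of 4-methoxyphenyl on a sulfonyl sulfur. Going by the values given here, no measured pair isolates this change, so these two values are the only guide. An estimated a number 6 percentage points lower from compound 2 to compound 3 (within the scatter) in this assay is expected to stay within the scatter. Compound 3 is estimated at 72% (expected range 58% to 86%).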

Compound 3, percent growth inhibition at one concentration: 71%
The estimate for compound 3 lay 1 percentage points above the measured number; measured number inside the range.
By their numbers in this assay, from the lowest: compounds 1, 3 and 2 (each within the scatter of the next).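

In this assay, 2-nitrophenyl in place of 4-methoxyphenyl on a sulfonyl sulfur gives a number 7 percentage points lower from compound 2 to compound 3 (within the scatter), so the two aryl groups are not separated at this position at the single concentration tested. Hydrogen in place of methoxy on an aromatic carbon gives a number 3 percentage points higher from compound 1 to compound 3 (within the scatter), so that position also shows no separation. Nothing available bears on a cause for either step.

As far as these compounds go, both groups on the sulfonyl sulfur are substituted phenyl rings, so it remains open whether a non-aromatic group such as methyl would hold growth inhibition. A single-concentration read-out also leaves potency differences within this set unresolved.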